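A few compounds are considered here, and "the series" means these few. Any claim that something is new, unique, unknown or untested is made for them only; others in the source may bear on it.

Three compounds have been examined for antiproliferative activity in an ADME assay on BJ cells (Homo sapiens) for antiproliferative activity, with a stated time of 72 h (on this read-out higher numbers stand for an effect only at larger amounts of compound and lower numbers for an effect already at smaller amounts), and none of them has returned a number. Compound 1 `COc1ccc(-c2c(I)c(=O)c3c(OC)cc(OC)cc3n2S(=O)(=O)c2ccc(OC)cc2)cc1` gives > 34400 nM, which is a limit of the assay rather than a measured value. Compound 2 `COC(=O)c1cc(=O)c2c(OC)cc(OC)cc2[nH]1` likewise gives only a limit, > 34400 nM. Compound 3 `COc1ccc(-c2cc(=O)c3c(OC)cc(OC)cc3n2S(=O)(=O)c2cccc([N+](=O)[O-])c2)cc1` stands at > 39600 nM, again a limit and not a number. Two of the three values thus sit at the limit of > 34400 nM in this assay, at which 2 of the 3 values shown sit, and the third at the limit of > 39600 nM in this assay, at which 1 of the 3 values shown sits, so compound 3 cannot be placed above or below its companions; all that is known is that none of them acted within the tested range.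

Compound 4 `COc1ccc(-c2cc(=O)c3c(OC)cc(OC)cc3n2S(=O)(=O)c2cccc(Br)c2)cc1` differs from compound 3 in one place: bromo in place of nitro on an aromatic carbon. Going by the values given here, no step between measured compounds exists to guide this change, and the values shown are limits only. The expectation for the step from compound 3 to compound 4 is therefore a step that the limit leaves unreadable from compound 3 to compound 4, nothing beyond the usual scatter. Compound 4 is accordingly estimated to give 50000 nM in this assay, with a range from 20000 nM to 150000 nM, most likely reported again as a limit.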

Compound 4, half-maximal effective concentration: > 58600 nM
Compound 4 ended at the assay's limit (the forecaster's own chance of this, stated with the estimate: 85%); middle value at least 1.1-fold (0.06 log units) away from the limit.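

Compound 3 and compound 4 both give only limits, so the step of bromo in place of nitro on an aromatic carbon cannot be read. The compounds shown leave open whether any of them would show an effect in this assay at larger amounts.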